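Permeability of furan-linked diamines: compound 3 to compound 4

The compounds below may be only part of what the source reports. "The series", "measured", "known", "first", "only" and "open" are said of these compounds alone.

Measured compounds and their values:
Compound 1, `Fc1ccc(Cc2ccc3c(NCCCNCc4ccco4)ccnc3c2)cc1`: 23 10^-6 cm/s
Compound 2, `Clc1ccc(Oc2ccc3c(NCCCNCc4ccco4)ccnc3c2)cc1`: 317 10^-6 cm/s
Compound 3, `COc1ccc(Oc2ccc3c(NCCCNCc4ccco4)ccnc3c2)cc1`: 317 10^-6 cm/s

All three share a common core; they differ only in the group on one aromatic carbon. In an ADME assay for permeability, using PAMPA, with a stated time of 30 min, at pH 7.4 (a lower number here means that the compound crosses the layer more slowly, a higher number that the compound crosses the layer faster), compound 1 gives 23 10^-6 cm/s. Compound 2 gives 317 10^-6 cm/s and compound 3 gives 317 10^-6 cm/s, so compound 3 stands level with compound 2 and together they give the highest of the three numbers, while compound 1 lies far below them.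

The measured steps show two things. The change a 14-fold higher number from compound 1 to compound 2 (1.14 log units; beyond the scatter) and the change a 14-fold higher number from compound 1 to compound 3 (1.14 log units; beyond the scatter) are both large, whereas the change no change at the digits printed from compound 2 to compound 3 (within the scatter) stays within the scatter.

Compound 4, `c1coc(CNCCCNc2ccnc3cc(-c4cccc5ccccc45)ccc23)c1`, has not yet been measured in this assay. It differs from compound 3 by naphthalen-1-yl in place of 4-methoxyphenoxy on an aromatic carbon. For the measured compounds named here, none of the measured steps replaces a phenoxy group by a directly attached ring, so the bearing of the known steps is indirect: the steps from compound 1 show that a change of the group at this position can move the number strongly, and compound 1, which also carries a carbon-linked ring, gave the lowest number.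

On that basis compound 4 is expected to fall somewhat below compound 3, with a 2.1-fold lower number from compound 3 to compound 4 (0.32 log units; beyond the scatter), and its value in this assay is estimated at 150 10^-6 cm/s, in the range 40 10^-6 cm/s to 400 10^-6 cm/s.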

Compound 4, apparent permeability: 237 10^-6 cm/s
For compound 4 the middle estimate is 1.6-fold (0.20 log units) below the measured one, and the stated range covers the measured number.
By their numbers in this assay, from the lowest: compound 1; then compounds 4, 2 and 3 (each within the scatter of the next).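

The new result shows that a ring system of carbon only, naphthalen-1-yl, joined directly to this aromatic carbon, can stand with the two phenoxy groups in this assay: there is a 1.3-fold lower number from compound 3 to compound 4 (0.13 log units; within the scatter) and a 1.3-fold lower number from compound 2 to compound 4 (0.13 log units; within the scatter) in the same assay. Neither oxygen of 4-methoxyphenoxy is therefore needed for a number in this range, since a group with no oxygen at all gives a value within the scatter of the two groups that carry it. Compound 1 now stands alone, with a 10-fold higher number from compound 1 to compound 4 (1.01 log units; beyond the scatter) on the other side of it, so a carbon atom joining the ring to the core does not by itself go with the low number, and among these four compounds only the 4-fluorobenzyl group is set apart.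

From the compounds shown here alone, it remains open whether an unsubstituted benzyl group would share the low number of compound 1, and how a piperazine or a carboxylic acid at this position would read in this assay. The data at hand offer no measurement that explains why compound 1 differs from the other three.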